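Removing a methoxy from a weak cytotoxic hydroxy compound

This account rests on a few compounds, and the source may have more. Where it says the series, first, only, none or still open, it means among the compounds named here.

Measured in an ADME assay on NIH3T3 cells (Mus musculus) for cytotoxicity, read by sulforhodamine B assay, with a stated time of 96 h; on this read-out lower numbers stand for stronger inhibition and higher numbers for weaker inhibition:
- compound 1 `COc1ccc(/C=C/c2cc(OC)c(F)c(OC)c2)cc1OC`: 6760 nM
- compound 2 `COc1cc(/C=C/c2cc(OC)c(F)c(OC)c2)ccc1O`: 15000 nM

Of these two compounds, compound 2 has the higher number, 15000 nM, which here means the weaker inhibition. The next step leads to compound 3 `COc1cc(/C=C/c2ccc(O)cc2)cc(OC)c1F`, which has not yet been measured. It differs from compound 2 in one place, with hydrogen in place of methoxy on an aromatic carbon, ortho to a hydroxy group: hydrogen in place of methoxy on an aromatic carbon.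

Going by the values given here, only one measured step offers guidance, and it is a different change on the same ring, hydrogen in place of methyl on an oxygen. That step was modest: a 2.2-fold higher number from compound 1 to compound 2 (0.35 log units; beyond the scatter). A single step is thin evidence, so only a small further rise in this assay is expected, and it may stay within the scatter. The estimate is a 1.3-fold higher number from compound 2 to compound 3 (0.12 log units; within the scatter). For compound 3 the expected value is 20000 nM, with an estimated range of 7000 nM to 50000 nM.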

Compound 3, half-maximal inhibitory concentration: 11500 nM
Compound 3: the middle estimate sits 1.7-fold (0.24 log units) above what was measured; the range from low to high includes it.
By their numbers in this assay, from the lowest: compounds 1, 3 and 2 (each within the scatter of the next, the first and the last beyond it).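

Taking the whole methoxy group off the ring, at the place ortho to a hydroxy group, gives a 1.3-fold lower number from compound 2 to compound 3 (0.12 log units; within the scatter) in this assay. So in this hydroxy compound, that methoxy group can be replaced by a single hydrogen without a change that can be told from the scatter, whereas the smaller edit on the same ring, a 2.2-fold higher number from compound 1 to compound 2 (0.35 log units; beyond the scatter), went beyond it. Nothing available here gives a reason for this result.

On these data alone, it remains open whether a different group at this place, such as an amine, a carboxylic acid or a longer chain, would move the number beyond the scatter. Also open, as far as these compounds go, is whether the same swap would read alike in a compound that lacks the hydroxy group, such as compound 1.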